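Methoxy in place of methyl on a fused core

The source may hold more compounds than are shown below. What is called first, only, known or untested is meant among the compounds shown, and "the series" means these compounds.

Compound 1 `COc1ccc2[nH]c(-c3ccc[nH]3)cc2c1` gives a point of reference: in a functional assay on U-373MG ATCC cells (Homo sapiens) for cytotoxicity, read by MTT assay, with a stated time of 72 h (on this read-out higher numbers stand for weaker inhibition and lower numbers for stronger inhibition), compound 1 gives 43000 nM. Compound 2 `Cc1ccc2[nH]c3c4cn[nH]c4c4c(c3c2c1)C(=O)NC4=O` yields no number in this assay; compound 2 gives only > 100000 nM, which is a limit of the assay, the line at which one of the two values sits (the limit of > 100000 nM in this assay, at which 1 of the 2 values shown sits). Compound 3 `COc1ccc2[nH]c3c4cn[nH]c4c4c(c3c2c1)C(=O)NC4=O` differs from compound 2 in a single place: methoxy in place of methyl on an aromatic carbon. Among the measured compounds shown here, with no measured step of this kind to lean on, the expected step that the limit leaves unreadable from compound 2 to compound 3 is taken as none beyond the scatter. Compound 3 is therefore expected to give 150000 nM, between 50000 nM and 500000 nM, quite possibly again only as a limit.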

Compound 3, half-maximal inhibitory concentration: 51000 nM
Compound 3: the middle estimate sits 2.9-fold (0.47 log units) above what was measured; measured number inside the range.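

With methoxy in place of methyl on an aromatic carbon of the shared core, the read-out becomes a measured number: in this assay compound 3 gives 51000 nM. The change carries an at least 1.9-fold lower number from compound 2 to compound 3 (0.29 log units; that floor lies within the scatter), so only a floor on the step is known and it does not clear the usual scatter. Compound 2 stands at a limit of the assay, which leaves the true size of the step unread: the limit of > 100000 nM in this assay, at which 1 of the 3 values shown sits.

On these data alone, what an amine, a hydroxyl or a longer chain on this same aromatic carbon would give stays open. As far as these compounds go, whether a carboxylic acid there would move the number further also remains unknown.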